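From Phenyl to Naphthalen-2-yl in Compound 4

The source may report more compounds than this note shows. Statements on the series, on what has been measured and on what is new or still open speak of the compounds shown alone.

Compound 1 `O=C1CS/C(=N\c2csc(-c3ccccc3)c2)N1` gives in a functional assay on MDA-MB-231 cells (Homo sapiens) for cytotoxicity, read by MTT assay, with a stated time of 72 h (on this read-out lower numbers stand for stronger inhibition and higher numbers for weaker inhibition), only a limit of the assay, > 50000 nM. Compound 2 `O=C1N/C(=N/c2csc(-c3ccc(Cl)cc3)c2)S/C1=C\c1ccccc1` gives 18000 nM. Compound 3 `COc1ccc(/C=C2\S/C(=N\c3csc(-c4ccc(Cl)cc4)c3)NC2=O)cc1` gives 1200 nM.

Compound 2 thus holds the highest of the two measured numbers, with compound 3 below it by a 15-fold lower number from compound 2 to compound 3 (1.18 log units; beyond the scatter). Compound 4 `O=C1N/C(=N/c2csc(-c3ccc(Cl)cc3)c2)S/C1=C\c1ccc2ccccc2c1` differs from compound 2 by naphthalen-2-yl in place of phenyl on a double-bonded chain carbon bound to a double-bonded ring carbon. Going by the values given here, only one measured step bears on this change: the step from compound 2 to compound 3 also reshapes the same phenyl, by adding a methoxy to it, and it was large. A smaller but still noticeable lowering in this assay is therefore expected for compound 4, amounting to a 2.6-fold lower number from compound 2 to compound 4 (0.41 log units; beyond the scatter). Compound 4 is estimated at 7000 nM, within 1500 nM to 30000 nM.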

Compound 4, half-maximal inhibitory concentration: 1800 nM
The estimate for compound 4 lay 3.9-fold (0.59 log units) above the measured number; the measured number falls inside the stated range.
By their numbers in this assay, from the lowest: compounds 3 and 4 (each within the scatter of the next); then compound 2. At a limit, above all of these: compound 1.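

The place on a double-bonded chain carbon bound to a double-bonded ring carbon accommodates a second fused aromatic ring: naphthalen-2-yl in place of phenyl gives a 10-fold lower number from compound 2 to compound 4 (1.00 log units; beyond the scatter) in this assay. The lowering seen with compound 3 is also not tied to a methoxy, as an all-carbon group with no hydrogen-bond acceptors gives a 1.5-fold higher number from compound 3 to compound 4 (0.18 log units; within the scatter). Nothing shown here accounts for this change.

As far as these compounds go, whether a carboxylic acid or an amine on the aromatic ring at this place would keep the number in this range remains open.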